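Isopropyl in place of cyano on the pendant ring

This account rests on a few compounds, and the source may have more. Where it says the series, first, only, none or still open, it means among the compounds named here.

Among the measured compounds shown here, compound 2 `Cc1c(NC2=NCCN2)cccc1-c1cccc(C#N)c1` gives 91.2 nM in an assay for binding affinity to Adrenergic receptor alpha-1 (Rattus norvegicus) (a lower number here means a stronger inhibitor, a higher number a weaker inhibitor), the highest of the two numbers measured so far; its nearest neighbour is compound 1 `COc1cccc(-c2cccc(NC3=NCCN3)c2C)c1`, which gives 43.7 nM in this assay. For the measured compounds named here, the only measured step between single-point changes is a 2.1-fold higher number from compound 1 to compound 2 (0.32 log units; beyond the scatter). Compound 3 `Cc1c(NC2=NCCN2)cccc1-c1cccc(C(C)C)c1` has not been measured; it differs from compound 2 by isopropyl in place of cyano on an aromatic carbon. Going by the values given here, no measured step covers this particular exchange, and the step from compound 1 to compound 2 concerns a different entering group, so it bears on compound 3 only in showing that exchanging the group at this aromatic carbon has so far shifted the number by a modest amount. A step of modest size is therefore expected, with the direction uncertain. For compound 3 the expected number is 60 nM, with a range from 20 nM to 180 nM. This estimate corresponds to an expected step of a 1.5-fold lower number from compound 2 to compound 3 (0.18 log units; within the scatter).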

Compound 3, inhibition constant: 1200 nM
Compound 3: the middle estimate sits 20-fold (1.30 log units) below what was measured, outside the stated range (above it).
By their numbers in this assay, from the lowest: compound 1; then compound 2; then compound 3.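

Replacing cyano with isopropyl gives a 13-fold higher number from compound 2 to compound 3 (1.12 log units; beyond the scatter) and replacing methoxy with isopropyl gives a 27-fold higher number from compound 1 to compound 3 (1.44 log units; beyond the scatter) in this assay on the same aromatic carbon. The earlier exchange of methoxy for cyano gave only a 2.1-fold higher number from compound 1 to compound 2 (0.32 log units; beyond the scatter) and so gave no sign that this position could respond so strongly to the group placed on it. Among the three groups shown, isopropyl therefore stands clearly apart from both methoxy and cyano, and the position is far less permissive than the first pair suggested.

As far as these compounds go, it remains open whether a methyl, an ethyl, a hydroxyl or an amine on this aromatic carbon would stay near compound 1 or move toward compound 3. No supporting measurement accompanies these results to show why isopropyl stands apart.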